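Three Measured Analogues and One Expected Value

A few compounds are considered here, and "the series" means these few. Any claim that something is new, unique, unknown or untested is made for them only; others in the source may bear on it.

Compound 1 `O=C(Nc1cccnc1)c1ccccc1OCc1cccc(F)c1` gives 1600 nM in an assay on lysate for inhibition of phosphatidylcholine:ceramide cholinephosphotransferase 2 (Homo sapiens), read by HPLC, with stated times of 30 min and 2 h; on this read-out lower numbers stand for stronger inhibition and higher numbers for weaker inhibition.
Compound 2 `O=C(Nc1cccnc1)c1ccccc1OCc1cccc(Cl)c1` gives 1400 nM.
Compound 3 `O=C(Nc1cccnc1)c1ccccc1OCc1cc(Cl)ccc1Cl` gives 990 nM.

Compound 3 carries the lowest of the three numbers, but the gaps are small: a 1.6-fold lower number from compound 1 to compound 3 (0.21 log units; within the scatter) and a 1.4-fold lower number from compound 2 to compound 3 (0.15 log units; within the scatter), so all three sit within the scatter of one another. Compound 4 `Cc1ccc(F)cc1COc1ccccc1C(=O)Nc1cccnc1` differs from compound 3 in one place: 5-fluoro-2-methylphenyl in place of 2,5-dichlorophenyl on a saturated chain carbon bound to an oxygen on an aromatic ring. Within the data shown here, two measured steps bear on this change. Swapping one halogen for another gave a 1.1-fold lower number from compound 1 to compound 2 (0.06 log units; within the scatter), and the added chlorine step noted above was equally small. Since neither left the scatter, putting fluorine back in place of chlorine and adding a methyl is expected to move the number little, if at all. Compound 4 is therefore estimated at 1300 nM, between 500 nM and 3500 nM, an expected step of a 1.3-fold higher number from compound 3 to compound 4 (0.12 log units; within the scatter).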

Compound 4, half-maximal inhibitory concentration: 740 nM
Beside the measured number, compound 4's estimate is 1.8-fold (0.24 log units) above it; the measured number falls inside the stated range.
By their numbers in this assay, from the lowest: compounds 4, 3, 2 and 1 (each within the scatter of the next, the first and the last beyond it).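

At this position, on a saturated chain carbon bound to an oxygen on an aromatic ring, a methyl and a fluorine serve as well as two chlorines: 5-fluoro-2-methylphenyl in place of 2,5-dichlorophenyl gives a 1.3-fold lower number from compound 3 to compound 4 (0.13 log units; within the scatter), and in place of 3-chlorophenyl it gives a 1.9-fold lower number from compound 2 to compound 4 (0.28 log units; within the scatter). Adding a methyl gives a 2.2-fold lower number from compound 1 to compound 4 (0.33 log units; beyond the scatter), a modest step and the first here to leave the scatter. Nothing measured here explains that step. Going by these compounds, whether an amine or a carboxylic acid on this aromatic ring, or a longer chain at this place, would move the number further remains open.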